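The source may hold more compounds than are shown below. What is called first, only, known or untested is meant among the compounds shown, and "the series" means these compounds.

Measured in a functional assay on HT-29 cells (Homo sapiens) for inhibition, read by MTT assay, with a stated time of 48 h; on this read-out higher numbers stand for weaker inhibition and lower numbers for stronger inhibition:

Compound 1 `COc1ccc(-n2c(SCC(=O)c3ccccc3)nnc2-c2cc(OC)c(OC)c(OC)c2)cc1`: > 60000 nM (a limit of the assay, not a number)
Compound 2 `COc1cc(-c2nnc(SCc3ccc(F)cc3)n2-c2ccc(N(C)C)cc2)cc(OC)c1OC`: 44300 nM

Among the compounds with values here, compound 2, at 44300 nM, holds the only true number so far. Next comes compound 3 `COc1cc(-c2nnc(SCC(=O)c3ccccc3)n2-c2ccc(N(C)C)cc2)cc(OC)c1OC`, which has not yet been measured. It carries benzoyl in place of 4-fluorophenyl on a saturated chain carbon bound to a sulfur. Cut one bond further out, the same change reads 4-fluorobenzyl to benzoylmethyl. Each group holds one six-membered aromatic ring of carbon only, and benzoyl brings a hydrogen-bond acceptor that 4-fluorophenyl lacks. Within the data shown here, no measured pair shows what such a swap does, so any forecast here is uncertain. A modest move towards stronger inhibition is expected, and a result within the usual scatter would be no surprise. The expected change is a 2.2-fold lower number from compound 2 to compound 3 (0.35 log units; beyond the scatter) in this assay. For compound 3 the estimate is 20000 nM, with an expected range of 2000 nM to 60000 nM.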

Compound 3, half-maximal inhibitory concentration: 45200 nM
Compound 3: middle estimate off by 2.3-fold (0.35 log units), on the low side; measured number inside the range.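

In this assay, benzoyl in place of 4-fluorophenyl on a saturated chain carbon bound to a sulfur gives a 1.0-fold higher number from compound 2 to compound 3 (0.01 log units; within the scatter), so the two groups cannot be told apart here, and the hydrogen-bond acceptor that benzoyl adds goes with no difference beyond the scatter. Dimethylamino in place of methoxy on an aromatic carbon gives an at least 1.3-fold lower number from compound 1 to compound 3 (0.12 log units; that floor lies within the scatter), which offers no clear sign of an effect from this change. Compound 1 stands only at a limit of the assay, so this step is a floor and its full size stays unknown: the limit of > 60000 nM in this assay, at which 1 of the 3 values shown sits.

From the compounds shown here alone, whether a carboxylic acid, an amine or a longer chain in place of benzoylmethyl would shift the number beyond the scatter remains open. Also open, going by these compounds, is how large the dimethylamino step truly is.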